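Thiophen-2-yl for cyclohexyl at the limit of measurement

The compounds below may be only part of what the source reports. "The series", "measured", "known", "first", "only" and "open" are said of these compounds alone.

In a physicochemical assay for pharmacokinetics (a lower number here means that the compound disappears faster, a higher number that the compound lasts longer), compound 3 `O=C(NCC1CCCCC1)N1C(=O)c2ccccc2S1(=O)=O` gives > 166 h, which is a limit and not a number. Compound 2 `O=C(c1ccccc1)N1C(=O)c2ccccc2S1(=O)=O` gives > 166 h, also a limit. That leaves compound 3 with the limit of > 166 h in this assay, at which 3 of the 3 values shown sit.

Compound 4 `O=C(NCc1cccs1)N1C(=O)c2ccccc2S1(=O)=O` changes one group of compound 3: thiophen-2-yl in place of cyclohexyl on a saturated chain carbon bound to an amide-type nitrogen. Cut one bond further out, this reads cyclohexylmethyl to (thiophen-2-yl)methyl.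

The measured step closest to this change exchanges a ring at the same place: a step that the two limits leave unreadable from compound 1 to compound 3. It therefore gives no size to carry over. Compound 1 `O=C(NCc1ccccc1F)N1C(=O)c2ccccc2S1(=O)=O`, which has an aromatic ring at this place, gives > 166 h, again a limit, so compound 4 is expected to reach the limit too. The estimated change is a step that the limit leaves unreadable from compound 3 to compound 4, with no step beyond the scatter and no direction expected. For compound 4 the expected half-life is 200 h, with an estimated range from 120 h to 400 h, and a limit rather than a number is the likely report.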

Compound 4, half-life: > 166 h
Compound 4: a limit, no number; the forecaster's own chance of this, stated with the estimate: 85%; the middle value does not contradict the limit.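

In this assay compound 4 gives > 166 h, a limit and not a number. Its steps from compound 1, compound 2 and compound 3 therefore cannot be read: the limit of > 166 h in this assay, at which 4 of the 4 values shown sit.

The compounds shown leave open how long each one actually lasts, and whether thiophen-2-yl, cyclohexyl or 2-fluorophenyl at this place changes the half-life at all.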